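The source may report more compounds than this note shows. Statements on the series, on what has been measured and on what is new or still open speak of the compounds shown alone.

Three compounds have been measured in a functional assay on HOP-62 cells (Homo sapiens) for inhibition, read by sulforhodamine B assay, with a stated time of 48 h; a lower number here means a stronger inhibitor of growth, a higher number a weaker inhibitor of growth:

compound 1, `Nc1cc(N)c2nc(-c3ccccc3)c(Oc3ccc(Cl)c(Cl)c3)nc2c1`, gives 38000 nM;
compound 2, `COc1ccc(CNc2nc3cc(N)cc(N)c3nc2-c2ccccc2)cc1OC`, gives 34700 nM;
compound 3, `Nc1cc(N)c2nc(-c3ccccc3)c(Sc3ccc(Cl)c(Cl)c3)nc2c1`, gives 77600 nM.

Compound 3 carries the highest number of the three, so it is the weakest growth inhibitor here. Its nearest neighbour is compound 1, which shares the whole core and differs only at one point: a 2.0-fold higher number from compound 1 to compound 3 (0.31 log units; beyond the scatter). Compound 2 differs from compound 3 at the same position but by a larger change, and its value sits close to that of compound 1.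

Compound 4, `Nc1cc(N)c2nc(-c3ccccc3)c(Sc3ccc(F)cc3)nc2c1`, keeps the sulfur link of compound 3 and changes the ring on it: 4-fluorophenyl in place of 3,4-dichlorophenyl on a sulfur. For the measured compounds named here, none of the measured steps alters the ring on the sulfur, so no step bears directly on this change; the one measured step concerns the linking atom, not the ring. The expectation therefore rests mainly on the weak activity of compound 3 itself, and the step is estimated as a 1.0-fold higher number from compound 3 to compound 4 (0.01 log units; within the scatter), that is, no change beyond the usual scatter, with wide uncertainty. Compound 4 is thus expected to give about 80000 nM, within a range from 30000 nM to 200000 nM.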

Compound 4, concentration for total growth inhibition: 34700 nM
Compound 4: the middle estimate sits 2.3-fold (0.36 log units) above what was measured; the range from low to high includes it.
By their numbers in this assay, from the lowest: compounds 2, 4 and 1 (each within the scatter of the next); then compound 3.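

In this assay, the ring on the sulfur proves to matter: 4-fluorophenyl in place of 3,4-dichlorophenyl gives a 2.2-fold lower number from compound 3 to compound 4 (0.35 log units; beyond the scatter) and so shows that this position responds to the ring as well as to the linking atom, the only feature varied by the earlier step, a 2.0-fold higher number from compound 1 to compound 3 (0.31 log units; beyond the scatter). Exchanging the whole group, (4-fluorophenyl)sulfanyl in place of 3,4-dichlorophenoxy, gives a 1.1-fold lower number from compound 1 to compound 4 (0.04 log units; within the scatter) and leaves the two compounds within the scatter of each other, so a sulfur link does not always come with a higher number than the oxygen-linked compound 1. No measurement offered here bears on what lies behind the ring effect.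

The ring change removes two chlorines and adds one fluorine together, so the compounds shown cannot separate the contribution of each atom or tell whether a single chlorine would behave like the fluorine. Also open, as far as these compounds go, is how the number would respond to a plain phenyl on the sulfur, or to a ring carrying an amine or a carboxylic acid.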